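A few compounds are considered here, and "the series" means these few. Any claim that something is new, unique, unknown or untested is made for them only; others in the source may bear on it.

Measured in a functional assay on PC-3 cells (Homo sapiens) for inhibition, read by sulforhodamine B assay, with a stated time of 48 h; on this read-out higher numbers stand for weaker inhibition of growth and lower numbers for stronger inhibition of growth:
- compound 1 `CC(C)(C)NCc1c(C(=O)O)nn(-c2ccccc2)c1-c1ccc(F)cc1`: > 680000 nM (a limit)
- compound 2 `Cc1ccc(-c2c(CNC(C)(C)C)c(C(=O)O)nn2-c2ccccc2)cc1`: > 688000 nM (a limit)

Compound 2 stands only at a limit, > 688000 nM, so no number is available for it. The other value in this short series is also a limit, as the limit of > 680000 nM in this assay, at which 1 of the 2 values shown sits, records.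

The next change gives compound 3 `COc1ccc(-c2c(CNC(C)(C)C)c(C(=O)O)nn2-c2ccccc2)cc1`. Its difference from compound 2 is methoxy in place of methyl on an aromatic carbon. This is methoxy in place of methyl on an aromatic carbon, para to a large group, or 4-methylphenyl to 4-methoxyphenyl.

For the measured compounds named here, one measured step bears on this change: a step that the two limits leave unreadable from compound 1 to compound 2. It is methyl in place of fluoro on an aromatic carbon, and its size cannot be read. It therefore gives no measured size or direction to carry over, and neither measured compound offers a number as a starting point.

With no readable step to draw on, no shift beyond the scatter is expected in this assay, and a further limit is the likely report. The expected outcome is an at least 1.0-fold lower number from compound 2 to compound 3 (0.01 log units; that floor lies within the scatter), an estimate with no direction favoured. For compound 3 the estimated value is 660000 nM, with an expected range of 300000 nM to 1000000 nM.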

Compound 3, concentration for 50% growth inhibition: > 659000 nM
Compound 3 was reported as a limit; the forecaster's own chance of this, stated with the estimate: 85%; the middle value lies beyond the limit too.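

In this assay compound 3 stands at > 659000 nM as a limit and not a number. With compound 1 and compound 2 also at limits, none of the steps among the three compounds can be read. The compounds shown leave open whether fluoro, methyl or methoxy on this aromatic carbon makes any difference to growth inhibition.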